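Hydrazone series in rat: a hydroxyphenyl enters the series

A few compounds are considered here, and "the series" means these few. Any claim that something is new, unique, unknown or untested is made for them only; others in the source may bear on it.

Measured compounds:
compound 1 `CC1CCC(=NNc2ccc(Cl)c(Cl)c2)c2ncc(C(=O)O)c(=O)n21`: > 100 umol/kg
compound 2 `Cc1cccc(Cl)c1NN=C1CCC(C)n2c1ncc(C(=O)O)c2=O`: > 100 umol/kg
compound 3 `Cc1cc(NN=C2CCC(C)n3c2ncc(C(=O)O)c3=O)ccc1Br`: > 100 umol/kg

In a functional assay on the whole organism with Rattus norvegicus as the target (on this read-out higher numbers stand for an effect only at larger amounts of compound and lower numbers for an effect already at smaller amounts), compound 1 gives > 100 umol/kg, a limit of the assay rather than a number. Compound 2 likewise gives only the limit > 100 umol/kg. Compound 3 also sits at the limit > 100 umol/kg. Accordingly the steps a step that the two limits leave unreadable from compound 1 to compound 2, a step that the two limits leave unreadable from compound 1 to compound 3 and a step that the two limits leave unreadable from compound 2 to compound 3 cannot be sized, and all three compounds are tied because of the limit of > 100 umol/kg in this assay, at which 3 of the 3 values shown sit.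

Compound 4 `CC1CCC(=NNc2cc(Cl)ccc2O)c2ncc(C(=O)O)c(=O)n21` differs from compound 3 by 5-chloro-2-hydroxyphenyl in place of 4-bromo-3-methylphenyl on an amine nitrogen. Going by the values given here, no measured step reads out for this change, so no direction can be drawn from the three compounds. The step from compound 3 to compound 4 is therefore expected to be a step that the limit leaves unreadable from compound 3 to compound 4, most likely with compound 4 again reported as a limit. Compound 4 is estimated at 150 umol/kg, with a range from 30 umol/kg to 600 umol/kg.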

Compound 4, dose for 50% inhibition: > 100 umol/kg
Compound 4: no number, only a limit; the forecaster's own chance of this, stated with the estimate: 70%; the middle value lies beyond the limit too.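

The steps from compound 1, compound 2 and compound 3 to compound 4 cannot be read, because all four compounds sit at the same limit: the limit of > 100 umol/kg in this assay, at which 4 of the 4 values shown sit.

The compounds shown leave open how the four substituted phenyl groups on the amine nitrogen rank against one another.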